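A few compounds are considered here, and "the series" means these few. Any claim that something is new, unique, unknown or untested is made for them only; others in the source may bear on it.

Measured so far, in a functional assay on the whole organism (Tail, strain ICR) with Mus musculus as the target, in the tail flick test, with a stated time of 30 min, at a dose of 25 umol/kg by the oral route; a lower number here means a weaker effect, a higher number a stronger effect of the compound at the dose given:

Compound 1, `O=C(OCc1ccccc1)[C@@H]1CCCN1C(=O)CN(c1nc(Cl)nc2[nH]cnc12)C1CC1`: 33.2%
Compound 2, `NCCCC[C@H](NC(=O)CN(c1nc(Cl)nc2[nH]cnc12)C1CC1)C(=O)OCc1ccccc1`: 26.1%
Compound 3, `CC(C)[C@H](NC(=O)CN(c1ncnc2c1ncn2C1CCCCO1)C1CC1)C(=O)OCc1ccccc1`: 21.8%

Among these three numbers, compound 3 stands at the bottom. The nearest number is that of compound 2, which lies within the usual scatter of the assay, so the two cannot be told apart. The furthest is that of compound 1, which lies beyond the scatter, so compound 1 does give a stronger effect in this assay than compound 3.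

The next compound, compound 4, `C[C@@H](O)[C@H](NC(=O)CN(c1ncnc2c1ncn2C1CCCCO1)C1CC1)C(=O)OCc1ccccc1`, is built from compound 3 by one change: 1-hydroxyethyl in place of isopropyl on a saturated chain carbon bound to an amide-type nitrogen and a carbonyl carbon. No step of this kind, from an isopropyl to a 1-hydroxyethyl on such a carbon, has been measured among these compounds, so there is nothing to set its size by. The change is small in count and sits away from the shared core, and the three measured numbers spread only modestly. The expected step is therefore a number 2.2 percentage points higher from compound 3 to compound 4 (within the scatter), within the scatter rather than beyond it, in no settled direction. Compound 4 is estimated to give 24% in this assay, with a range from 10% to 40%.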

Compound 4, a percentage reported as activity, at one dose (the size of the read-out at that dose, not a potency): 23.6%
The estimate for compound 4 lay 0.4 percentage points above the measured number; low and high end bracket the measured number.
By their numbers in this assay, from the lowest: compounds 3, 4, 2 and 1 (each within the scatter of the next, the first and the last beyond it).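

In this assay, putting 1-hydroxyethyl in place of isopropyl on a saturated chain carbon bound to an amide-type nitrogen and a carbonyl carbon gives a number 1.8 percentage points higher from compound 3 to compound 4 (within the scatter), so the two compounds cannot be told apart. Going by these compounds alone, this is the first pair here that differs in one place, and it shows that this position accepts a group with one hydrogen-bond donor, one hydrogen-bond acceptor and a defined stereocentre, none of which isopropyl has, without a difference in the read-out beyond the usual scatter. No supporting measurement is available to account for this result, so it stands as an observation only.

On these data alone, only this one replacement can be read at this position, so it remains open whether a different group there, such as an amine, a carboxylic acid or a longer chain, would give a step beyond the scatter. As far as these compounds go, it also remains open whether the same replacement would give a similar step on the core of compound 2, or at any other dose in this test.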